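Dichlorophenyl in place of dimethylphenyl on the triazole

The source may hold more compounds than are shown below. What is called first, only, known or untested is meant among the compounds shown, and "the series" means these compounds.

Compound 1 `COc1cc2c(Oc3ccc(NC(=O)c4cn(-c5c(Cl)cccc5Cl)nn4)cc3F)ccnc2cc1OCCCN1CCCCC1` in a functional assay on HT-29 cells (Homo sapiens) for cytotoxicity, read by MTT assay, with a stated time of 72 h (a higher number here means a weaker inhibitor, a lower number a stronger inhibitor), gives 240 nM
Compound 2 `COc1cc2c(Oc3ccc(NC(=O)c4cn(-c5c(C)cccc5C)nn4)cc3F)ccnc2cc1OCCCN1CCC(C)CC1` in this assay gives 2450 nM

Compound 2 stands at the higher of the two numbers, the weaker of the pair, with compound 1 at a far lower value, beyond the scatter. Compound 3 `COc1cc2c(Oc3ccc(NC(=O)c4cn(-c5c(Cl)cccc5Cl)nn4)cc3F)ccnc2cc1OCCCN1CCC(C)CC1` is not yet measured. Its difference from compound 2 is 2,6-dichlorophenyl in place of 2,6-dimethylphenyl on an aromatic nitrogen. Since compound 1 also carries the 2,6-dichlorophenyl and gives 240 nM, compound 3 is expected to land between the two measured values, closer to compound 1. The expected step in this assay is downward, a 4.9-fold lower number from compound 2 to compound 3 (0.69 log units; beyond the scatter), beyond the scatter. Compound 3 is estimated at 500 nM, within 150 nM to 1500 nM.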

Compound 3, half-maximal inhibitory concentration: 1390 nM
For compound 3 the middle estimate is 2.8-fold (0.44 log units) below the measured one, within the range that was stated.
By their numbers in this assay, from the lowest: compound 1; then compounds 3 and 2 (each within the scatter of the next).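

Exchanging 2,6-dimethylphenyl for 2,6-dichlorophenyl on this aromatic nitrogen makes little measurable difference in this assay (a 1.8-fold lower number from compound 2 to compound 3 (0.25 log units; within the scatter)), so the choice between these two groups is not decisive here. The other change, methyl in place of hydrogen on a saturated ring carbon, does register clearly (a 5.8-fold higher number from compound 1 to compound 3 (0.76 log units; beyond the scatter)). No measured evidence is available to explain either step. Still open, going by these compounds, is how an unsubstituted phenyl on the aromatic nitrogen, or a hydroxyl or an amine in place of that methyl, would behave in this assay (the same cytotoxicity read-out).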